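The source may report more compounds than this note shows. Statements on the series, on what has been measured and on what is new or still open speak of the compounds shown alone.

In a functional assay on HeLa cells (Homo sapiens) for inhibition, read by MTT assay, with a stated time of 72 h (on this read-out higher numbers stand for weaker inhibition and lower numbers for stronger inhibition), compound 3 `Cn1cc(-c2cnc(N)c(Oc3ccc(C(=O)Nc4cccc(Cl)c4)cc3)n2)cn1` gives 4460 nM, the lowest of the three numbers measured. Compound 1 `Cn1cc(-c2cnc(N)c(Oc3ccc(C(=O)Nc4ccccc4)cc3)n2)cn1`, which carries an unsubstituted phenyl ring on the amide nitrogen, gives 12300 nM, and compound 2 `Cn1cc(-c2cnc(N)c(Oc3ccc(C(=O)Nc4ccccc4Cl)cc3)n2)cn1` gives 73000 nM. The step of a 2.8-fold lower number from compound 1 to compound 3 (0.44 log units; beyond the scatter) and the step of a 5.9-fold higher number from compound 1 to compound 2 (0.77 log units; beyond the scatter) show that adding a chlorine to that ring can move the number in either direction, and the step of a 16-fold lower number from compound 2 to compound 3 (1.21 log units; beyond the scatter) shows how much depends on where that chlorine is placed. Compound 4 `Cn1cc(-c2cnc(N)c(Oc3ccc(C(=O)Nc4cccc(Cl)n4)cc3)n2)cn1` differs from compound 3 by 6-chloropyridin-2-yl in place of 3-chlorophenyl on an amide-type nitrogen. For the measured compounds named here, none of the measured steps exchanges a ring carbon for a ring nitrogen, and none moves a chlorine together with such an exchange; the measured steps speak only to the chlorine on an otherwise unchanged phenyl ring. A ring change of this kind is not covered by compounds 1, 2 and 3. A modest step in either direction appears the most likely outcome in this assay, with a weakening judged somewhat more probable than a strengthening. Compound 4 is expected to give 7000 nM, within a range from 1500 nM to 30000 nM. That estimate amounts to an expected step of a 1.6-fold higher number from compound 3 to compound 4 (0.20 log units; within the scatter).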

Compound 4, half-maximal inhibitory concentration: 38200 nM
Beside the measured number, compound 4's estimate is 5.5-fold (0.74 log units) below it; the measured number lies above the stated range.
By their numbers in this assay, from the lowest: compound 3; then compound 1; then compounds 4 and 2 (each within the scatter of the next).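

In this assay the ring on the amide-type nitrogen proves sensitive to more than the place of its chlorine: 6-chloropyridin-2-yl in place of 3-chlorophenyl, a change that brings one ring nitrogen and one hydrogen-bond acceptor, gives an 8.6-fold higher number from compound 3 to compound 4 (0.93 log units; beyond the scatter) and so loses the advantage seen with compound 3. The change also takes the number past that of the unsubstituted phenyl ring, with a 3.1-fold higher number from compound 1 to compound 4 (0.49 log units; beyond the scatter) showing that a chlorine-bearing ring can end up weaker than the plain one even when it is not 2-chlorophenyl. Against 2-chlorophenyl, the new ring gives a 1.9-fold lower number from compound 2 to compound 4 (0.28 log units; within the scatter) and the two cannot be told apart, so two different changes to the ring of compound 3 end at a similar level.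

Nothing shown here explains why the ring nitrogen has this effect. Going by these compounds, it also stays open whether the loss belongs to the ring nitrogen alone, which a plain pyridin-2-yl ring without chlorine would test, and whether a methoxy or an amino group in place of the chlorine on either ring would behave the same way.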